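The source may report more compounds than this note shows. Statements on the series, on what has been measured and on what is new or still open speak of the compounds shown alone.

The measured compounds in this set:

Compound 1, `CC1(C)[C@H]2CC[C@]1(C)N(Cc1cn(-c3ccccc3Br)nn1)C(=O)C2` — 60 nM
Compound 2, `CC1(C)[C@H]2CC[C@]1(C)N(Cc1cn(-c3ccc(C#N)cc3)nn1)C(=O)C2` — 90 nM

Compound 1 holds the lower of the two numbers in a functional assay on LoVo cells (Homo sapiens) for inhibition, read by MTT assay, with a stated time of 24 h (a lower number here means a stronger inhibitor, a higher number a weaker inhibitor), but it stands apart from compound 2 by no more than the scatter, as the step of a 1.5-fold higher number from compound 1 to compound 2 (0.18 log units; within the scatter) shows. The unmeasured compound 3, `CC1(C)[C@H]2CC[C@]1(C)N(Cc1cn(-c3ccccc3)nn1)C(=O)C2`, differs from compound 1 in one place: hydrogen in place of bromo on an aromatic carbon. Within the data shown here, the only measured step, from compound 1 to compound 2, replaces one group by another on the same ring and stays within the scatter, which speaks for a ring that tolerates variation at these positions. Among the measured compounds shown here, no measured step removes a group outright, so the bearing of that step on compound 3 is indirect. The step expected from compound 1 to compound 3 is therefore a modest one, a 1.8-fold higher number from compound 1 to compound 3 (0.26 log units; within the scatter), leaning towards a somewhat higher number but not clearly beyond the scatter. Compound 3 is estimated at 110 nM in this assay, with a likely range from 45 nM to 300 nM.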

Compound 3, half-maximal inhibitory concentration: 50 nM
The estimate for compound 3 lay 2.2-fold (0.34 log units) above the measured number; the range from low to high includes it.
By their numbers in this assay, from the lowest: compounds 3, 1 and 2 (each within the scatter of the next).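

In this assay, among these compounds, this is the first measured step that takes a group away outright instead of exchanging it for another, and removing the bromo from an aromatic carbon ortho to a large group stays within the scatter (a 1.2-fold lower number from compound 1 to compound 3 (0.08 log units; within the scatter)). Hydrogen in place of cyano also stays within the scatter (a 1.8-fold lower number from compound 2 to compound 3 (0.26 log units; within the scatter)), so among these three compounds neither the bromo nor the cyano group is needed for a number of this size, and the plain phenyl of compound 3 cannot be told apart from either substituted ring. Nothing measured on these compounds offers an explanation for this tolerance.

The compounds shown leave open whether an amine, a carboxylic acid or a longer chain on the same ring would also stay within the scatter or would produce the first clear step in this series. They also leave open how the number responds to changes away from this ring, such as replacing the phenyl with a saturated ring or altering the shared core of compound 3.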